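The compounds below may be only part of what the source reports. "The series", "measured", "known", "first", "only" and "open" are said of these compounds alone.

Notes on the coumarin-amide series, step from compound 1 to compound 4.

Compound 1 `CCNCCCOc1ccc2cc(NC(=O)c3ccc(O)c(CC=C(C)C)c3)c(=O)oc2c1C` is the reference. In a functional assay on MCF7 cells (Homo sapiens) for antiproliferative activity (a higher number here means a weaker inhibitor, a lower number a stronger inhibitor), compound 1 gives 980 nM, the lowest of the two numbers that are numbers. Compound 2 `CCN(C)CCCOc1ccc2cc(NC(=O)c3ccc(O)c(CC=C(C)C)c3)c(=O)oc2c1C` gives 2190 nM in this assay, so that a 2.2-fold higher number from compound 1 to compound 2 (0.35 log units; beyond the scatter). Compound 3 `CCCN(CCC)CCCOc1ccc2cc(NC(=O)c3ccc(O)c(CC=C(C)C)c3)c(=O)oc2c1C` reaches only the limit of the assay, > 50000 nM, in this assay; (the limit of > 50000 nM in this assay, at which 1 of the 3 values shown sits). From this an at least 51-fold higher number from compound 1 to compound 3 (1.70 log units; beyond the scatter) and an at least 22-fold higher number from compound 2 to compound 3 (1.35 log units; beyond the scatter), so every enlargement of the amine substituents on the chain has so far weakened inhibition, modestly for the methyl, strongly for the dipropylamino.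

Compound 4 `CC(C)=CCc1cc(C(=O)Nc2cc3ccc(OCCCNCC(=O)O)c(C)c3oc2=O)ccc1O` keeps the secondary amine of compound 1 and differs in that (carboxy in place of methyl on a saturated chain carbon bound to an amine nitrogen). Among the measured compounds shown here, no measured step changes the chain carbon bound to the amine nitrogen; the steps to compound 2 and compound 3 change only the nitrogen itself. The nearest guide is therefore the modest step from compound 1 to compound 2, taken as a sign that any added group at the amine end costs potency, with the step size uncertain. For compound 4 a weakening of a 4.6-fold higher number from compound 1 to compound 4 (0.66 log units; beyond the scatter) is expected, giving an estimated 4500 nM with a range of 1200 nM to 25000 nM.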

Compound 4, half-maximal inhibitory concentration: 18100 nM
Compound 4: the middle estimate sits 4.0-fold (0.60 log units) below what was measured, within the range that was stated.
By their numbers in this assay, from the lowest: compound 1; then compound 2; then compound 4. At a limit, above all of these: compound 3.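

In this assay, among the compounds shown here, carboxy in place of methyl on a saturated chain carbon bound to an amine nitrogen gives an 18-fold higher number from compound 1 to compound 4 (1.27 log units; beyond the scatter), so this carbon, which no earlier step touched, does not tolerate the change without loss. Against the ethyl(methyl)amino chain the (carboxymethyl)amino chain also falls behind, with an 8.3-fold higher number from compound 2 to compound 4 (0.92 log units; beyond the scatter), yet it stays ahead of the dipropylamino chain, with an at least 2.7-fold lower number from compound 3 to compound 4 (0.44 log units; beyond the scatter). That last step is only a bound, since compound 3 stands at a limit of the assay: the limit of > 50000 nM in this assay, at which 1 of the 4 values shown sits.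

Still open, on these data alone, is whether the loss follows from the carboxylic acid itself or from any larger group at this carbon, a question that a methyl ester or a primary amide in its place would address. Also open, as far as these compounds go, is how the number would move with a longer chain between the amine nitrogen and the carboxy group.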